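Amide series: 2-fluorophenyl to 3,4-dihydroxyphenyl

The source may hold more compounds than are shown below. What is called first, only, known or untested is meant among the compounds shown, and "the series" means these compounds.

Compound 1 `Cc1cc(-c2ccccc2)nc2nc(NC(=O)c3ccccc3F)nn12` gives > 250000 nM (a limit)
Compound 2 `Cc1cc(-c2ccccc2)nc2nc(C(=O)Nc3ccccc3F)nn12` gives > 250000 nM (a limit)

In an ADME assay on MDCK cells (Canis lupus familiaris) for cytotoxicity, read by MTT assay, with a stated time of 48 h (on this read-out higher numbers stand for lower toxicity in this test and lower numbers for higher toxicity in this test), compound 1 gives > 250000 nM as a limit of the assay and not as a number. Compound 2 gives > 250000 nM as a limit too. Compound 1 therefore stands at the limit of > 250000 nM in this assay, at which 2 of the 2 values shown sit, and has no numerical value.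

Compound 3 `Cc1cc(-c2ccccc2)nc2nc(NC(=O)c3ccc(O)c(O)c3)nn12` keeps the core of compound 1 and changes the group on a carbonyl carbon: 3,4-dihydroxyphenyl in place of 2-fluorophenyl on a carbonyl carbon is the whole difference. Among the compounds with values here, no measured step is available to size this change. In this assay the expected shift is small, either within the scatter or a modest move toward lower numbers, and an at least 1.3-fold lower number from compound 1 to compound 3 (0.14 log units; that floor lies within the scatter) is the step expected here. The half-maximal cytotoxic concentration of compound 3 is estimated at 180000 nM with an expected range from 70000 nM to 250000 nM in this test, and a reading at the limit would be no surprise.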

Compound 3, half-maximal cytotoxic concentration: 112000 nM
Beside the measured number, compound 3's estimate is 1.6-fold (0.21 log units) above it; the range from low to high includes it.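

In this assay, within the data shown here, the group on a carbonyl carbon turns out to matter: 3,4-dihydroxyphenyl in place of 2-fluorophenyl brings an at least 2.2-fold lower number from compound 1 to compound 3 (0.34 log units; beyond the scatter), and this is the first reading that is a number, on the side of higher toxicity in this test. The change therefore moves the read-out even though the core of compound 1 stays the same. The step gives only a floor for the shift and not its full size, because compound 1 stands at a limit: the limit of > 250000 nM in this assay, at which 2 of the 3 values shown sit.

From the compounds shown here alone, it remains open whether the shift follows from losing the 2-fluorophenyl group or from gaining the 3,4-dihydroxyphenyl group. Also open, going by these compounds, is how a phenyl group with a single hydroxyl, or one with an amine or a carboxylic acid, would read at this position.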